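The compounds below may be only part of what the source reports. "The series", "measured", "known", "first", "only" and "open" are said of these compounds alone.

Measured in an assay on HepG2 cells for activation of nuclear factor erythroid 2-related factor 2 (Homo sapiens), read by a luciferase reporter, with a stated time of 5 h; on this read-out lower numbers stand for an effect already at smaller amounts and higher numbers for an effect only at larger amounts of compound:

Compound 1 `COc1cccc(/C=C/c2cccc(F)c2)c1`: 2300 nM
Compound 2 `COc1cccc(/C=C/c2cccc(F)c2)c1OC`: 1900 nM
Compound 3 `COc1cccc(/C=C/c2ccccc2OC)c1`: 4400 nM

Compounds 1 and 2 differ in one place, (methoxy in place of hydrogen on an aromatic carbon), and the step is a 1.2-fold lower number from compound 1 to compound 2 (0.08 log units; within the scatter). The difference between the core of compound 1 and the core of compound 3 is not broken down here; their two values both lie in the same region.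

Compound 4 `COc1cccc(/C=C/c2cc(OC)ccc2OC)c1` is not yet measured. It differs from compound 3 by methoxy in place of hydrogen on an aromatic carbon. Within the data shown here, this is the same kind of change as the one from compound 1 to compound 2, but not the same: there the new methoxy sat ortho to a group of 9 heavy atoms and ortho to a methoxy group, whereas here it sits meta to a large group and para to a methoxy group.

Because the earlier step of a 1.2-fold lower number from compound 1 to compound 2 (0.08 log units; within the scatter) stayed within the scatter, the step from compound 3 to compound 4 is expected to be small as well, about a 1.2-fold lower number from compound 3 to compound 4 (0.09 log units; within the scatter). Compound 4 is therefore estimated to give 3600 nM in this assay, with a plausible range from 1500 nM to 8500 nM.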

Compound 4, half-maximal effective concentration: > 15000 nM
Compound 4 gave a limit, no number; the forecaster's own chance of this, stated with the estimate: 10%; middle value at least 4.1-fold (0.61 log units) away from the limit.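

In this assay, the same swap of hydrogen for methoxy gives an at least 3.4-fold higher number from compound 3 to compound 4 (0.53 log units; beyond the scatter), so the small step seen earlier did not carry over from one core to the other: the same change on two cores in this assay, a 1.2-fold lower number (0.08 log units; within the scatter) from compound 1 to compound 2 and an at least 3.4-fold higher number (0.53 log units; beyond the scatter) from compound 3 to compound 4, at least 4.1-fold (0.61 log units) apart, beyond the scatter of two such steps

Compound 4 gives > 15000 nM, which is a limit of the assay and not a number.

What this does not show is the reason for the difference: the new methoxy in compound 4 sits meta to a large group and para to a methoxy group, and two steps cannot separate the effect of that place from the effect of the different core.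

The compounds shown leave open whether a methoxy at the same place on the core of compound 1 would also raise the number. They also leave open whether a hydroxyl or an amine at that place on the core of compound 3 would give a step like the one seen with methoxy.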